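A Chlorophenyl Variant in a Urea Hydrazone Series

The source may hold more compounds than are shown below. What is called first, only, known or untested is meant among the compounds shown, and "the series" means these compounds.

In a functional assay on NCI-H460 cells (Homo sapiens) for cytotoxicity, read by MTT assay, with a stated time of 72 h (a higher number here means a weaker inhibitor, a lower number a stronger inhibitor), compound 1 `CN(C)CCn1cnnc1-c1cc(Oc2ccc(NC(=O)N/N=C/c3cc(C(C)(C)C)cc(C(C)(C)C)c3O)cc2F)ccn1` gives 590 nM.
In this assay compound 2 `CN(C)CCn1cnnc1-c1cc(Oc2ccc(NC(=O)N/N=C/c3ccccc3O[N+](=O)[O-])cc2F)ccn1` gives 1270 nM.
In this assay compound 3 `COc1cc(/C=N/NC(=O)Nc2ccc(Oc3ccnc(-c4nncn4CCN(C)C)c3)c(F)c2)cc(OC)c1OC` gives 2770 nM.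

Compound 2 holds the middle number of the three: compound 1 sits lower, compound 3 higher, and the measured step of a 2.2-fold higher number from compound 2 to compound 3 (0.34 log units; beyond the scatter) is modest but beyond the scatter. Compound 4 `CN(C)CCn1cnnc1-c1cc(Oc2ccc(NC(=O)N/N=C/c3ccc(Cl)cc3)cc2F)ccn1` differs from compound 2 by 4-chlorophenyl in place of 2-(nitrooxy)phenyl on a carbon with a double bond to nitrogen. Within the data shown here, the only measured step that touches the same place is the one to compound 3, so the expectation for compound 4 is a small change in this assay, in either direction, likely within the scatter. For compound 4 the estimate is 1300 nM, with a range from 550 nM to 3000 nM, which means an expected step of a 1.0-fold higher number from compound 2 to compound 4 (0.01 log units; within the scatter).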

Compound 4, half-maximal inhibitory concentration: 320 nM
For compound 4 the middle estimate is 4.1-fold (0.61 log units) above the measured one; the whole stated range lies above it.
By their numbers in this assay, from the lowest: compounds 4 and 1 (each within the scatter of the next); then compound 2; then compound 3.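

In this assay, the carbon with a double bond to nitrogen now proves able to carry a group that lowers the number, since 4-chlorophenyl gives a clear drop (a 4.0-fold lower number from compound 2 to compound 4 (0.60 log units; beyond the scatter)) and a larger one against the trimethoxy analogue (an 8.7-fold lower number from compound 3 to compound 4 (0.94 log units; beyond the scatter)). Among these compounds, until now, the only step at this position went upward. Nothing measured here explains the drop. The compounds shown leave open whether the chlorine itself matters, and a plain phenyl or a 4-fluorophenyl at this position would help separate its contribution from that of the ring.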